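This account rests on a few compounds, and the source may have more. Where it says the series, first, only, none or still open, it means among the compounds named here.

Measured compounds:
- compound 1, `Fc1ccc(CSc2nnc(-c3ccncc3)n2-c2ccccc2)c(F)c1`: 11400 nM
- compound 2, `O=C(CSc1nnc(-c2ccncc2)n1-c1ccccc1)N/N=C/c1ccccc1`: 14700 nM

Both numbers come from a functional assay on HCT-116 cells (Homo sapiens) for inhibition, read by MTT assay, with a stated time of 48 h; a higher number here means a weaker inhibitor, a lower number a stronger inhibitor. In this assay compound 2 gives 14700 nM, the higher of the two numbers; its nearest neighbour is compound 1, which gives 11400 nM, and the gap between the two lies within the scatter of repeated measurements, so the two compounds cannot be told apart on these numbers.

Compound 3, `O=C(CSc1nnc(-c2ccncc2)n1-c1ccccc1)N/N=C/c1ccc([N+](=O)[O-])cc1`, has not yet been measured. It keeps the shared core and the hydrazone part of compound 2 and differs in one place: nitro in place of hydrogen on an aromatic carbon. The new group sits on the outer phenyl, para to a large group, so it is nitro in place of hydrogen on an aromatic carbon.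

Going by the values given here, no step between two measured compounds is available, so there is nothing to calibrate the size of this change against. The expectation for compound 3 is therefore a step of a 1.3-fold lower number from compound 2 to compound 3 (0.13 log units; within the scatter), that is, no change beyond the scatter in either direction. Compound 3 is expected to give 11000 nM, within a range from 3500 nM to 35000 nM.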

Compound 3, half-maximal inhibitory concentration: 10200 nM
Compound 3: middle estimate off by 1.1-fold (0.03 log units), on the high side; measured number inside the range.
By their numbers in this assay, from the lowest: compounds 3, 1 and 2 (each within the scatter of the next).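

Going by these compounds alone, replacing hydrogen with nitro on the outer phenyl, para to a large group, gives the first step that can be read between two compounds differing in one place: in this assay the change from phenyl to 4-nitrophenyl comes with a 1.4-fold lower number from compound 2 to compound 3 (0.16 log units; within the scatter) and therefore cannot be told apart from repeat-to-repeat variation. This shows that adding nitro at this position leaves the number without a detectable change, although the group brings in heavy atoms and hydrogen-bond acceptors that hydrogen lacks. No measurement is available to explain why the two compounds read alike.

The compounds shown leave open whether a different group at this same place, such as an amine, a carboxylic acid or a methoxy group, would produce a step beyond the scatter. With a single step at this position, they also cannot show whether the number responds to any change there or whether nitro is simply one of several groups that make no detectable difference.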